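The compounds below may be only part of what the source reports. "The series", "measured", "known", "first", "only" and "open" are said of these compounds alone.

Measured compounds in an assay on isolated protein for inhibition of 2-Hydroxyacid oxidase 2 (Homo sapiens), tested at 1 uM; a lower number here means a weaker effect, a higher number a stronger effect of the compound at the concentration tested:
compound 1, `Cc1n[nH]c(C(=O)O)c1Cc1cccc(C(F)(F)F)c1`: 5%
compound 2, `Cc1n[nH]c(C(=O)O)c1Cc1ccc(-c2ccc(F)cc2)cc1`: 11%
compound 3, `Cc1n[nH]c(C(=O)O)c1Cc1ccc(-c2ccc(C(F)(F)F)cc2)cc1`: 5%

Compound 3 stands level with compound 1 at the digits shown, the two together the lowest of the three numbers in this assay; compound 2 differs from compound 3 only within the scatter. Compound 4, `Cc1n[nH]c(C(=O)O)c1Cc1ccc(-c2ccc(OC(F)(F)F)cc2)cc1`, differs from compound 3 in one place: trifluoromethoxy in place of trifluoromethyl on an aromatic carbon. Going by the values given here, the one measured step that bears on it, a number 6 percentage points lower from compound 2 to compound 3 (within the scatter), changed a group on the same aromatic carbon and stayed within the scatter. Among the compounds with values here, no measured pair exchanges trifluoromethyl for trifluoromethoxy. The step from compound 3 to compound 4 is therefore expected to be a number 1 percentage points higher from compound 3 to compound 4 (within the scatter), nothing beyond the scatter. Compound 4 is estimated at 6%, with a range from -5% to 17%.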

Compound 4, a percentage reported as inhibition, at one concentration (the size of the read-out at that concentration, not a potency): 11%
Beside the measured number, compound 4's estimate is 5 percentage points below it; measured number inside the range.
By their numbers in this assay, from the lowest: compounds 1, 3, 2 and 4 (each within the scatter of the next).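

In this assay, trifluoromethoxy on this aromatic carbon, para to a large group, gives a number 6 percentage points higher from compound 3 to compound 4 (within the scatter) and no change at the digits printed from compound 2 to compound 4 (within the scatter). Fluoro, trifluoromethyl and trifluoromethoxy at this position therefore cannot be told apart in this read-out, and replacing trifluoromethyl with trifluoromethoxy produces no change beyond the scatter. Nothing available here offers an explanation for this result.

As far as these compounds go, whether an amine or a nitrile at this position would shift this assay beyond the scatter remains open. So does whether any change at this position can separate compounds in this read-out at all.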